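Propoxy analogue in the alkoxybenzamide pyridine series

This account rests on a few compounds, and the source may have more. Where it says the series, first, only, none or still open, it means among the compounds named here.

Measured compounds:
- compound 1 `C=CCOc1ccc(C(=O)Nc2cccc(C)n2)cc1`: 6000 nM
- compound 2 `C=C(C)COc1ccc(C(=O)Nc2cccc(C)n2)cc1`: 19600 nM
- compound 3 `CCOc1ccc(C(=O)Nc2cc(C)cc(C)n2)cc1`: 17100 nM

In an in vitro assay on HEK-tsA201 cells for antagonist activity at Neuronal acetylcholine receptor; alpha4/beta2 (Homo sapiens), read by fluorescence and calcium flux (on this read-out higher numbers stand for weaker inhibition and lower numbers for stronger inhibition), compound 2 gives the highest number of the three. Compound 3 stands closest to it and within the scatter, so no order between compound 2 and compound 3 can be read. Compound 1 stands furthest away: the step of a 3.3-fold higher number from compound 1 to compound 2 (0.51 log units; beyond the scatter) is beyond the scatter.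

Compound 4 `CCCOc1ccc(C(=O)Nc2cccc(C)n2)cc1` is not yet measured. It differs from compound 2 in one place: ethyl in place of 1-methylethenyl on a saturated chain carbon bound to an oxygen on an aromatic ring. For the measured compounds named here, the only measured step that bears on this change is a 3.3-fold higher number from compound 1 to compound 2 (0.51 log units; beyond the scatter), where the same methyl on the double-bonded chain carbon raised the number. Going by the values given here, compound 4 removes that methyl again, but also lacks the double bond, and no measured pair shows what that does; compound 3 shows only that a short saturated alkoxy chain, with a differently substituted core, sits close to compound 2.

The expected step is therefore a modest lowering, a 2.5-fold lower number from compound 2 to compound 4 (0.39 log units; beyond the scatter), bringing compound 4 toward compound 1. Compound 4 is estimated at 8000 nM in this assay, with a range from 3000 nM to 22000 nM.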

Compound 4, half-maximal inhibitory concentration: 7500 nM
Compound 4: middle estimate off by 1.1-fold (0.03 log units), on the high side; the range from low to high includes it.
By their numbers in this assay, from the lowest: compounds 1 and 4 (each within the scatter of the next); then compounds 3 and 2 (each within the scatter of the next).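

In this assay, ethyl in place of vinyl on the saturated chain carbon bound to the aromatic-ring oxygen gives a small step (a 1.3-fold higher number from compound 1 to compound 4 (0.10 log units; within the scatter)), which lies within the scatter, so on this chain the double bond can give way to a fully saturated propoxy chain with no readable change. Ethyl in place of 1-methylethenyl gives a larger step (a 2.6-fold lower number from compound 2 to compound 4 (0.42 log units; beyond the scatter)), which lies beyond the scatter, so of the three chains on the shared core, only the one carrying 1-methylethenyl stands apart. Nothing available on these compounds accounts for this difference.

As far as these compounds go, whether a longer chain such as butoxy stays within the scatter of compound 4 remains open. So does whether a terminal amine on the propoxy chain would be tolerated at this position.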